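Methyl on the Hydrazone Phenyl: What Compound 4 Might Give

This account rests on a few compounds, and the source may have more. Where it says the series, first, only, none or still open, it means among the compounds named here.

Compound 3 `CC1=CC[C@@H]([C@@](C)(O)CCCC(C)(C)NC(=S)N/N=C\c2ccccc2)CC1` gives the lowest number of the three measured compounds in a functional assay on MCF7 cells (Homo sapiens) for cytotoxicity, read by sulforhodamine B assay (a lower number here means a stronger inhibitor of growth, a higher number a weaker inhibitor of growth), at 7720 nM. Compound 1 `CC1=CC[C@@H]([C@@](C)(O)CCCC(C)(C)NC=S)CC1` gives 16000 nM in this assay, and compound 2 `CC1=CC[C@@H]([C@@](C)(O)CCCC(C)(C)NC(=S)NN)CC1` gives 15300 nM. The steps of a 2.1-fold lower number from compound 1 to compound 3 (0.32 log units; beyond the scatter) and a 2.0-fold lower number from compound 2 to compound 3 (0.30 log units; within the scatter) lowered the number only modestly, while a 1.0-fold lower number from compound 1 to compound 2 (0.02 log units; within the scatter) left it essentially unchanged. Compound 4 `CC1=CC[C@@H]([C@@](C)(O)CCCC(C)(C)NC(=S)N/N=C\c2ccc(C)cc2)CC1` differs from compound 3 by methyl in place of hydrogen on an aromatic carbon, on the phenyl that entered in those earlier steps. Among the compounds with values here, no measured step bears directly on a substituent placed on this phenyl, so only a small shift, if any beyond the scatter, is expected. Compound 4 is therefore estimated at 6500 nM in this assay, with a range from 3000 nM to 14000 nM. That estimate means an expected step of a 1.2-fold lower number from compound 3 to compound 4 (0.07 log units; within the scatter).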

Compound 4, concentration for 50% growth inhibition: 7230 nM
Compound 4: middle estimate off by 1.1-fold (0.05 log units), on the low side; low and high end bracket the measured number.
By their numbers in this assay, from the lowest: compounds 4, 3, 2 and 1 (each within the scatter of the next, the first and the last beyond it).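

In this assay, methyl in place of hydrogen on the aromatic ring gives a 1.1-fold lower number from compound 3 to compound 4 (0.03 log units; within the scatter), so this small addition, para to a large group, leaves the number effectively where it was. Replacing the terminal nitrogen of compound 2 with the full 4-methylphenyl-bearing group gives a 2.1-fold lower number from compound 2 to compound 4 (0.33 log units; beyond the scatter), still only a modest step. No available measurement offers a reason for this flat result. Going by these compounds, whether a methoxy, an amine or a carboxylic acid at this same place would shift the number stays open.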